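Phenyl for Phenethyl and Permeability in a Small Series

The source may report more compounds than this note shows. Statements on the series, on what has been measured and on what is new or still open speak of the compounds shown alone.

Three compounds built on one shared core were measured in an ADME assay for permeability, using PAMPA, with a stated time of 30 min, at pH 7.4; on this read-out higher numbers stand for higher permeability and lower numbers for lower permeability. Compound 1 `COc1cccc(CNCCCNc2ccnc3cc(-c4ccccc4)ccc23)c1O` gives 237 10^-6 cm/s in that assay. Compound 3 `COc1cccc(CNCCCNc2ccnc3cc(CCc4ccccc4)ccc23)c1O` gives 23 10^-6 cm/s, and compound 2 `COc1ccc(F)cc1CNCCCNc1ccnc2cc(CCc3ccccc3)ccc12` gives 23 10^-6 cm/s in the same assay. Compound 3 and compound 1 differ only by phenyl in place of phenethyl on an aromatic carbon, and that change made a 10-fold higher number from compound 3 to compound 1 (1.01 log units; beyond the scatter) in this assay. Compound 3 and compound 2 differ by 5-fluoro-2-methoxyphenyl in place of 2-hydroxy-3-methoxyphenyl on a saturated chain carbon bound to an amine nitrogen, a change that gave no change at the digits printed from compound 2 to compound 3 (within the scatter) in this assay.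

Compound 4 `COc1ccc(F)cc1CNCCCNc1ccnc2cc(-c3ccccc3)ccc12` has not yet been measured in this assay. It stands to compound 2 as compound 1 stands to compound 3, differing by phenyl in place of phenethyl on an aromatic carbon, the same change at the same place. Because the earlier change made a 10-fold higher number from compound 3 to compound 1 (1.01 log units; beyond the scatter) in this assay, a step of about the same size is expected from the fluorinated pair, namely a 10-fold higher number from compound 2 to compound 4 (1.00 log units; beyond the scatter) in this assay. Compound 4 is therefore estimated at 230 10^-6 cm/s in this assay, with an expected range from 100 10^-6 cm/s to 450 10^-6 cm/s in this assay.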

Compound 4, apparent permeability: 237 10^-6 cm/s
Compound 4: the middle estimate sits 1.0-fold (0.01 log units) below what was measured; the range from low to high includes it.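

In this assay, phenyl in place of phenethyl on an aromatic carbon gave a 10-fold higher number from compound 2 to compound 4 (1.01 log units; beyond the scatter), and the step on this core matches the earlier one: the same change on two cores in this assay, a 10-fold higher number (1.01 log units; beyond the scatter) from compound 3 to compound 1 and a 10-fold higher number (1.01 log units; beyond the scatter) from compound 2 to compound 4, 1.0-fold (0.00 log units) apart, within the scatter of two such steps. The other change, 5-fluoro-2-methoxyphenyl in place of 2-hydroxy-3-methoxyphenyl, gave no change at the digits printed from compound 1 to compound 4 (within the scatter), and it also reads the same whichever group stands on the aromatic carbon: the same change on two cores in this assay, no change at the digits printed (within the scatter) from compound 2 to compound 3 and no change at the digits printed (within the scatter) from compound 4 to compound 1, 1.0-fold (0.00 log units) apart, within the scatter of two such steps. Within these four compounds, then, each change carried from one core to the other with its size intact, but two pairs do not show that it would hold on any further core or in any other assay, and they do not explain the size of the phenyl step.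

The compounds shown leave open how a benzyl group or a longer chain in place of phenethyl would read in this assay. They also leave open whether the phenyl step would persist if that phenyl carried an amine or a carboxylic acid.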